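Cyclohexyl amide replacing pyridinyl amide in the series

The source may report more compounds than this note shows. Statements on the series, on what has been measured and on what is new or still open speak of the compounds shown alone.

Compound 1 `COc1cccc(OC)c1C(=O)Nc1c[nH]nc1C(=O)Nc1ccncc1` is the starting point. In an ADME assay on MRC5 cells (Homo sapiens) for inhibition, with a stated time of 72 h (a lower number here means that less compound is needed, a higher number that more compound is needed for the effect), compound 1 gives > 50000 nM, which is a limit of the assay and not a number. Compound 2 `CO[C@H]1CC[C@H](NC(=O)c2n[nH]cc2NC(=O)c2ccc(N3CCCC3)cc2)CC1` also reaches only a limit in this assay, at > 50000 nM. Thus two of the three values sit at the limit of > 50000 nM in this assay, at which 2 of the 3 values shown sit. Compound 3 `COc1ccccc1C(=O)Nc1c[nH]nc1C(=O)N[C@H]1CC[C@H](OC)CC1`, which carries a cyclohexyl amide, gives 1500 nM in this assay. Compound 4 `COc1cccc(OC)c1C(=O)Nc1c[nH]nc1C(=O)N[C@H]1CC[C@H](O)CC1` has not been measured; it differs from compound 1 by 4-hydroxycyclohexyl in place of pyridin-4-yl on an amide-type nitrogen. Going by the values given here, no measured pair shares exactly this change, so the size of the step rests on expectation alone. Compound 1 sits at a limit. The step of an at least 8.3-fold lower number from compound 1 to compound 4 (0.92 log units; beyond the scatter) is expected to run toward a measurable value, guided by compound 3 with 1500 nM. Compound 4 is estimated at 6000 nM, between 1200 nM and 40000 nM.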

Compound 4, half-maximal effective concentration: 34000 nM
Compound 4: the middle estimate sits 5.7-fold (0.75 log units) below what was measured; the measured number falls inside the stated range.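

In this assay, with 4-hydroxycyclohexyl in place of pyridin-4-yl on an amide-type nitrogen, compound 4 gives 34000 nM, a number rather than a limit. For compound 1, > 50000 nM is a limit of the assay and not a number. The change can therefore be read only as a floor, an at least 1.4-fold lower number from compound 1 to compound 4 (0.16 log units; that floor lies within the scatter), and this does not establish a real shift at this position. Still open, as far as these compounds go, is whether an amine or a carboxylic acid in place of the hydroxyl on the cyclohexyl ring would change the value.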